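The source may report more compounds than this note shows. Statements on the series, on what has been measured and on what is new or still open speak of the compounds shown alone.

The measured compounds and their values:

compound 1, `Cc1c(Br)sc(N)c1C(=O)c1ccc(Cl)cc1`: 1%
compound 2, `CC(C)(C)Cc1c(-c2cccc(F)c2F)sc(N)c1C(=O)c1ccc(Cl)cc1`: 1%
compound 3, `CC(C)(C)Cc1c(-c2cc(F)ccc2F)sc(N)c1C(=O)c1ccc(Cl)cc1`: 1%

All three share one core and were tested in an assay on CHO cells for displacement of a labelled ligand from adenosine receptor A3 (Homo sapiens), read by scintillation counting, tested at 10 uM; on this read-out lower numbers stand for less inhibition and higher numbers for more inhibition at the one concentration tested (going by the name of the read-out). Compound 3 gives 1%, which is level with compound 1 and compound 2 within the scatter; none of the three stands apart from the others. For the measured compounds named here, the only step measured between two compounds that differ in a single place is the one from compound 2 to compound 3, where a 2,5-difluorophenyl replaced a 2,3-difluorophenyl, and it showed no change at the digits printed from compound 2 to compound 3 (within the scatter).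

Compound 4, `COc1ccccc1-c1sc(N)c(C(=O)c2ccc(Cl)cc2)c1CC(C)(C)C`, has not yet been measured. It differs from compound 3 in one place: 2-methoxyphenyl in place of 2,5-difluorophenyl on an aromatic carbon. Going by the values given here, no measured step involves a 2-methoxyphenyl, so the only guide is that swapping one substituted phenyl for another, from compound 2 to compound 3, left this assay flat, and the whole series sits at the bottom of the scale. The step from compound 3 to compound 4 is therefore expected to be a number 1 percentage points higher from compound 3 to compound 4 (within the scatter), that is, nothing beyond the scatter. Compound 4 is estimated at 2%, within a range from -6% to 12%.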

Compound 4, a percentage reported as inhibition, at one concentration (the size of the read-out at that concentration, not a potency): 1%
For compound 4 the middle estimate is 1 percentage points above the measured one; the range from low to high includes it.
By their numbers in this assay, from the lowest: compounds 1, 2, 3 and 4 (each within the scatter of the next).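

In this assay, the step at the aromatic carbon next to the ring sulfur now swaps atoms rather than moving fluorines around the ring: 2-methoxyphenyl, with its oxygen and one hydrogen-bond acceptor, enters where 2,5-difluorophenyl carried none, and the result is no change at the digits printed from compound 3 to compound 4 (within the scatter). Set against the other difluorinated compound, the same group gives no change at the digits printed from compound 2 to compound 4 (within the scatter), so this position has stayed flat for a change of substituent type as well as for a change of fluorine placement. Nothing measured here offers a reason for this flat result.

All these values lie at the bottom of the scale, where any further loss would not show, so it remains unclear whether this position matters at all. Going by these compounds, whether an amine, a carboxylic acid or a longer chain on this carbon would raise the number stays open.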